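The source may hold more compounds than are shown below. What is called first, only, known or untested is meant among the compounds shown, and "the series" means these compounds.

Compound 1 `Fc1ccccc1Nc1nc2nonc2nc1Nc1ccccc1`: 2200 nM in an assay on mitochondria from L6 cells (Rattus norvegicus) for activation, with a stated time of 90 min; a higher number here means that more compound is needed for the effect, a lower number that less compound is needed
Compound 2 `Cc1ccccc1Nc1nc2nonc2nc1Nc1ccccc1F`: 1100 nM in this assay
Compound 3 `Cc1ccc(Nc2nc3nonc3nc2Nc2ccccc2F)cc1`: 2100 nM in this assay

Compound 3 stands second highest of these three numbers, and all three lie within the scatter of one another: a 1.0-fold lower number from compound 1 to compound 3 (0.02 log units; within the scatter) and a 1.9-fold higher number from compound 2 to compound 3 (0.28 log units; within the scatter). Compound 4 `COc1cccc(Nc2nc3nonc3nc2Nc2ccccc2F)c1` differs from compound 3 by 3-methoxyphenyl in place of 4-methylphenyl on a nitrogen on an aromatic ring. Within the data shown here, no measured step involves a methoxy group. The steps that alter the ring on that nitrogen, a 2.0-fold lower number from compound 1 to compound 2 (0.30 log units; within the scatter), a 1.0-fold lower number from compound 1 to compound 3 (0.02 log units; within the scatter) and a 1.9-fold higher number from compound 2 to compound 3 (0.28 log units; within the scatter), all stayed within the scatter. In this assay no step beyond the scatter is therefore expected for compound 4. Compound 4 is estimated at 2000 nM, with a range from 800 nM to 5000 nM. The expected step is a 1.1-fold lower number from compound 3 to compound 4 (0.02 log units; within the scatter), within the scatter.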

Compound 4, half-maximal effective concentration: 830 nM
For compound 4 the middle estimate is 2.4-fold (0.38 log units) above the measured one; the range from low to high includes it.
By their numbers in this assay, from the lowest: compounds 4, 2, 3 and 1 (each within the scatter of the next, the first and the last beyond it).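

In this assay, among these compounds, a change to the ring on this nitrogen goes beyond the scatter for the first time: 3-methoxyphenyl in place of 4-methylphenyl brings a 2.5-fold lower number from compound 3 to compound 4 (0.40 log units; beyond the scatter), and set against the unsubstituted ring, the same group brings a 2.7-fold lower number from compound 1 to compound 4 (0.42 log units; beyond the scatter). In place of 2-methylphenyl, however, 3-methoxyphenyl brings only a 1.3-fold lower number from compound 2 to compound 4 (0.12 log units; within the scatter), so a methyl group on the ring can match it. No measurement on hand accounts for these steps. Still open, as far as these compounds go, is whether the lower number belongs to the methoxy group or to where it sits on the ring, and how an amine or a carboxylic acid on that ring would compare.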